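Swapping the aryl on the core carbon: an expected clearance

The compounds below may be only part of what the source reports. "The series", "measured", "known", "first", "only" and "open" are said of these compounds alone.

The measured compounds in an ADME assay on microsomes from liver (Homo sapiens) for metabolic stability, tested at 2.5 uM; a lower number here means slower removal, a higher number faster removal of the compound:
compound 1, `COc1ccc(-c2c(S(=O)(=O)c3cc(F)cc(F)c3)cnc3cc(F)ccc23)cc1`, 1.51 mL/min
compound 2, `COc1ccc(-c2c(S(=O)(=O)c3ccc(OC)cc3)cnc3cc(F)ccc23)cc1`, 1.18 mL/min
compound 3, `COc1ccc(-c2c(S(=O)(=O)c3ccc(C)c(C)c3)cnc3cc(F)ccc23)cc1`, 4.13 mL/min

Compound 2 gives the lowest of the three numbers, though its gap to compound 1, a 1.3-fold lower number from compound 1 to compound 2 (0.11 log units; within the scatter), lies within the scatter, so the two cannot be ordered. Compound 3 stands apart: a 2.7-fold higher number from compound 1 to compound 3 (0.44 log units; beyond the scatter) and a 3.5-fold higher number from compound 2 to compound 3 (0.54 log units; beyond the scatter) are both beyond the scatter, modest in size.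

Compound 4, `COc1ccc(S(=O)(=O)c2cnc3cc(F)ccc3c2-c2cccc(F)c2)cc1`, is not yet measured. It differs from compound 2 as follows: 3-fluorophenyl in place of 4-methoxyphenyl on an aromatic carbon. Among the compounds with values here, every measured step changes the group on the sulfonyl sulfur, and none touches the aromatic carbon of the core where compound 4 differs, so no step bears on this change directly. Within the data shown here, the only guidance is indirect: compound 1 carries fluorines on its aryl and sits within the scatter of compound 2, while the larger shifts seen with compound 3 came from a different group at a different place. With nothing pointing to a change beyond the scatter, compound 4 is expected to stay close to compound 2, with a 1.1-fold higher number from compound 2 to compound 4 (0.04 log units; within the scatter) as the estimated step. Compound 4 is therefore estimated at 1.3 mL/min, in the range 0.6 mL/min to 2.8 mL/min.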

Compound 4, intrinsic clearance in a liver preparation (reported as CLH), per the amount of preparation that the assay uses: 2.94 mL/min
For compound 4 the middle estimate is 2.3-fold (0.35 log units) below the measured one, outside the stated range (above it).
By their numbers in this assay, from the lowest: compounds 2, 1, 4 and 3 (each within the scatter of the next, the first and the last beyond it).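

In this assay, the step at the aromatic carbon of the core, opposite the ring nitrogen, is a 2.5-fold higher number from compound 2 to compound 4 (0.40 log units; beyond the scatter), with 3-fluorophenyl in place of 4-methoxyphenyl and the 4-methoxyphenyl on the sulfonyl sulfur unchanged. The earlier compounds shown here varied only the group on the sulfonyl sulfur, and this result shows that the aryl on the core carbon can also move the number beyond the scatter, by a step that is likewise modest in size. Nothing measured for these compounds accounts for the rise, so it remains an observation tied to this single swap.

The compounds shown leave open whether the rise follows from losing the 4-methoxyphenyl or from gaining the 3-fluorophenyl, and whether it would persist with 3,5-difluorophenyl or 3,4-dimethylphenyl on the sulfonyl sulfur. They also leave open how this assay would respond to a different kind of group on this core carbon, such as a pyridine ring, or a phenyl ring carrying an amine or a carboxylic acid.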